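A few compounds are considered here, and "the series" means these few. Any claim that something is new, unique, unknown or untested is made for them only; others in the source may bear on it.

The shared core, seen in `O=C(NCCCN1CCN(CCCNc2ccnc3cc(Cl)ccc23)CC1)c1ccc(Oc2ccccc2)cc1` as compound 1, carries a diamine chain capped by an amide, and the series varies the group on that amide carbonyl. In an ADME assay on L6 cells (Rattus norvegicus) for cytotoxicity (a lower number here means a stronger inhibitor, a higher number a weaker inhibitor), compound 1 gives 1400 nM. Compound 2, `NC(=O)c1ccc(C(=O)NCCCN2CCN(CCCNc3ccnc4cc(Cl)ccc34)CC2)cc1`, puts a 4-carbamoylphenyl group on the carbonyl carbon, but in this assay compound 2 gives "not determined" (no result reported), so nowhere on the numbers can it be placed. Compound 3, `CC(=O)CCC(=O)NCCCN1CCN(CCCNc2ccnc3cc(Cl)ccc23)CC1`, is the next step: 2-acetylethyl in place of 4-carbamoylphenyl on a carbonyl carbon. Among the compounds with values here, because no measured pair in this assay differs in only one place, there is no recorded step to lean on, and the size of this one can only be guessed. The expectation is a modest move toward a weaker effect, of a size that may still sit inside the usual scatter. For compound 3 the estimated value in this assay is 3000 nM, with a likely range from 800 nM to 12000 nM.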

Compound 3, half-maximal inhibitory concentration: 11000 nM
Beside the measured number, compound 3's estimate is 3.7-fold (0.56 log units) below it, within the range that was stated.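

Within the data shown here, no step from compound 2 to compound 3 can be read in this assay. The compounds shown leave open how far replacing 4-carbamoylphenyl with 2-acetylethyl on the carbonyl carbon shifts this read-out. Nothing available explains the value of compound 3.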